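The source may hold more compounds than are shown below. What is called first, only, known or untested is meant among the compounds shown, and "the series" means these compounds.

Four compounds that share one core were compared in a functional assay on cells (Endothelial cell, Sus scrofa) for antiproliferative activity; on this read-out lower numbers stand for stronger inhibition and higher numbers for weaker inhibition. Compound 1 `CO[C@@H]1[C@H](OC(=O)NC(=O)CCl)CO[C@]2(COC(C)(C)O2)[C@@]1(OC(=O)CCl)C1(C)CO1` gives 122000 nM. Compound 2 `CO[C@@H]1[C@H](OC(=O)NC(=O)CCl)CO[C@]2(COC(C)(C)O2)[C@@]1(OC(=O)NC(=O)CCl)C1OC1CCCc1ccccc1` gives 16000 nM, the lowest of the two single numbers, and compound 1 stands beyond the usual scatter above it. Compound 3 `CO[C@@H]1[C@H](OC(=O)NC(=O)CCl)CO[C@]2(COC(C)(C)O2)[C@@]1(O)C1OC1CCCc1ccccc1` was tested repeatedly and gives 68000 nM; 90000 nM (2 entries); its repeated entries the several entries of compound 3 in this assay, 68000 nM; 90000 nM (2 entries) differ somewhat, yet both stay well above compound 2. Compound 4 `CO[C@@H]1[C@H](OC(=O)NC(=O)CCl)CO[C@]2(COC(C)(C)O2)[C@]1(CCCCCc1ccccc1)OC(=O)NC(=O)CCl` has not yet been measured. It differs from compound 2 in one place (5-phenylpentyl in place of 3-(3-phenylpropyl)oxiran-2-yl on a saturated ring carbon). Among the compounds with values here, no measured pair shows this change, so the expectation rests on guesswork; a weakening beyond the scatter in this assay seems more likely than a gain. Compound 4 is expected to give 60000 nM, between 20000 nM and 200000 nM. The estimated step is a 3.8-fold higher number from compound 2 to compound 4 (0.57 log units; beyond the scatter).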

Compound 4, half-maximal inhibitory concentration: 800 nM
Estimate against measurement, compound 4: 75-fold (1.88 log units) above; the measured number lies below the stated range.
By their numbers in this assay, from the lowest: compound 4; then compound 2; then compound 1.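

In this assay, putting 5-phenylpentyl in place of 3-(3-phenylpropyl)oxiran-2-yl on this saturated ring carbon gives a 20-fold lower number from compound 2 to compound 4 (1.30 log units; beyond the scatter), a large gain. This position therefore accepts a plain carbon chain ending in a phenyl ring, and compound 4 shows that the three-membered oxygen ring is not needed for activity here. The data shown offer no explanation for the gain.

From the compounds shown here alone, whether a shorter or a longer chain would do as well remains open. So does the effect of an amine or a carboxylic acid at the end of the chain.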